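This account rests on a few compounds, and the source may have more. Where it says the series, first, only, none or still open, it means among the compounds named here.

Measured in an ADME assay on cells (Homo sapiens) for cytotoxicity, read by resazurin assay, with a stated time of 5 days; on this read-out lower numbers stand for higher toxicity in this test and higher numbers for lower toxicity in this test:
Compound 1 `COc1ccc(-c2nc(COc3cccc(Cl)c3)nc3ccsc23)cn1`: > 50000 nM
Compound 2 `O=S(=O)(Cc1nc(-c2ccncc2)c2sccc2n1)c1cccc(Cl)c1`: > 50000 nM

Each entry is a limit of the assay and not a number. Compound 2 therefore has no exact position on this scale, and neither does compound 1. The two measured compounds share one reading: the limit of > 50000 nM in this assay, at which 2 of the 2 values shown sit.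

Compound 3 `O=S(=O)(Cc1nc(-c2ccoc2)c2sccc2n1)c1cccc(Cl)c1` has furan-3-yl in place of pyridin-4-yl on an aromatic carbon, next to the ring nitrogen: furan-3-yl in place of pyridin-4-yl on an aromatic carbon. Among the compounds with values here, no measured pair shows what a change at this place does in this assay. The expectation rests on compound 2 at > 50000 nM, and no change beyond the scatter is expected. The estimated step is a number no higher from compound 2 to compound 3 (the limit leaves the size open). A reading at the same limit is the likeliest result. For compound 3 the expected value is 50000 nM, with an estimated range of 20000 nM to 80000 nM.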

Compound 3, half-maximal cytotoxic concentration: > 50000 nM
Compound 3 ended at the assay's limit (the forecaster's own chance of this, stated with the estimate: 75%); the middle value sits exactly at the limit.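

No step can be read between compound 2 and compound 3, since each gives only a limit in this assay and not a number: the limit of > 50000 nM in this assay, at which 3 of the 3 values shown sit. The compounds shown leave open at what concentration any of them would harm these cells, and which change would bring a reading within the range of this test.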